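Replacing an Oxazole Ring with Ethyl: Oral Bioavailability Outlook

This account rests on a few compounds, and the source may have more. Where it says the series, first, only, none or still open, it means among the compounds named here.

Of the compounds shown here, two sharing one core have been measured in an ADME assay on the whole organism (strain Wistar Han) for pharmacokinetics, with Rattus norvegicus as the target, read by LC-MS, at a dose of 10 mg/kg by the oral route; on this read-out lower numbers stand for lower oral bioavailability and higher numbers for higher oral bioavailability. Compound 1 `N#Cc1ccc(C(O)(c2cocn2)C(F)(F)F)cc1C(F)(F)F` gives 83% in this assay. Compound 2 `Cc1c(C(O)(c2cocn2)C(F)(F)F)ccc(C#N)c1C(F)(F)F` gives 100% in this assay. For the measured compounds named here, of these two numbers, compound 1 stands lowest, and the only other number lies higher, as a number 17 percentage points higher from compound 1 to compound 2 (beyond the scatter) shows, a change brought about by a methyl in place of hydrogen on an aromatic carbon.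

Compound 3 `CCC(O)(c1ccc(C#N)c(C(F)(F)F)c1)C(F)(F)F` has not yet been measured in this assay. It differs from compound 1 in one place: ethyl in place of 1,3-oxazol-4-yl on a saturated chain carbon bound to an aromatic carbon, an oxygen on a saturated carbon and a saturated chain carbon. Compound 3 thus keeps the core of compound 1 but carries an ethyl where compound 1 carries the five-membered aromatic ring with two hetero atoms.

Going by the values given here, the single measured step alters a group on an aromatic carbon and leaves the saturated chain carbon untouched, so no measured step bears on the change from compound 1 to compound 3, and the data give no direction for it. Given the number of compound 1 as the only anchor, a step of a number 8 percentage points lower from compound 1 to compound 3 (within the scatter) is expected, with a wide range. For compound 3 the estimate is 75%, within a range from 45% to 100%.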

Compound 3, oral bioavailability: 70%
For compound 3 the middle estimate is 5 percentage points above the measured one, within the range that was stated.
By their numbers in this assay, from the lowest: compound 3; then compound 1; then compound 2.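

In this assay, for the compounds shown here, this is the first measured change at the saturated chain carbon, and it gives a direction that the earlier compounds could not: putting ethyl in place of 1,3-oxazol-4-yl gives a number 13 percentage points lower from compound 1 to compound 3 (beyond the scatter). Compound 3, which has ethyl and no five-membered aromatic ring at this position, still gives 70%, so in this series the ring can be given up at a real but limited cost on this read-out. No measurement of any underlying property comes with this step, so the numbers record the size of the change and not its origin.

This single swap alters the ring, the heavy-atom count and the hydrogen-bond acceptor count all at once, so it cannot show which of these matters. As far as these compounds go, it also remains open where an amine or a longer chain on this carbon would fall, and whether the methyl on the aromatic carbon that separates compound 2 from compound 1 would have the same effect alongside ethyl.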